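Acetyl in Place of Nitro on the Far Ring

The compounds below may be only part of what the source reports. "The series", "measured", "known", "first", "only" and "open" are said of these compounds alone.

Compound 1 `Oc1cccc2cc(-c3ccccc3)ccc12` gives 20% in an assay for binding affinity to 17-beta-hydroxysteroid dehydrogenase type 2 (Homo sapiens), with a stated time of 20 min, tested at 1 uM; on this read-out lower numbers stand for less inhibition and higher numbers for more inhibition at the one concentration tested (going by the name of the read-out).
Compound 2 `Oc1cccc2cc(-c3ccc(F)cc3)ccc12` gives < 10% in this assay, which is a limit of the assay and not a number.
Compound 3 `O=[N+]([O-])c1ccc(-c2ccc3c(O)cccc3c2)cc1` gives 13% in this assay.

Of the two compounds with a number, compound 3 stands nearest compound 1, and a number 7 percentage points lower from compound 1 to compound 3 (within the scatter). The reading of compound 2 is only a limit (the limit of < 10% in this assay, at which 1 of the 3 values shown sits).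

Compound 4 `CC(=O)c1ccc(-c2ccc3c(O)cccc3c2)cc1` differs from compound 3 in one place: acetyl in place of nitro on an aromatic carbon. The measured steps that touch the same place are a number 7 percentage points lower from compound 1 to compound 3 (within the scatter), a number at least 10 percentage points lower from compound 1 to compound 2 (that floor lies within the scatter) and a number at least 3 percentage points higher from compound 2 to compound 3 (that floor lies within the scatter). None of them brings in an acetyl group, and none of them moves the read-out beyond the scatter. On that footing, no change beyond the scatter is expected for compound 4, so the expected step is a number 2 percentage points higher from compound 3 to compound 4 (within the scatter). Compound 4 is therefore estimated to give 15% in this assay, with a range from 5% to 30%.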

Compound 4, a percentage reported as inhibition, at one concentration (the size of the read-out at that concentration, not a potency): < 10%
Compound 4 was reported as a limit; the forecaster's own chance of this, stated with the estimate: 25%; at least 5 percentage points between middle value and limit.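

Going by these compounds alone, compound 4 brings the first acetyl group to this place, on an aromatic carbon para to a large group, and in this assay compound 4 gives < 10% which is a limit of the assay and not a number. Acetyl in place of nitro gives a number at least 3 percentage points lower from compound 3 to compound 4 (that floor lies within the scatter) and acetyl in place of hydrogen gives a number at least 10 percentage points lower from compound 1 to compound 4 (that floor lies within the scatter) so acetyl adds a further group at this place without any step shown beyond the scatter. The step between compound 2 and compound 4 cannot be read, and the limit now recurs at this place: the limit of < 10% in this assay, at which 2 of the 4 values shown sit.

Going by these compounds, whether any group at this place can raise the read-out beyond the scatter stays open, and an amine, a carboxylic acid or a longer chain would bear on that. On these data alone, whether compound 2 and compound 4 differ from each other also stays open.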